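Swapping fluoro for a large aryl group

This account rests on a few compounds, and the source may have more. Where it says the series, first, only, none or still open, it means among the compounds named here.

Compound 1 `COc1cccc(NC(=O)c2cc(=O)[nH]c3cc(Br)ccc23)c1`: > 20000 nM (a limit)
Compound 2 `O=C(Nc1cccc(F)c1)c1cc(=O)[nH]c2cc(F)ccc12`: > 20000 nM (a limit)
Compound 3 `O=C(Nc1cc(F)cc(F)c1)c1cc(=O)[nH]c2cc(F)ccc12`: > 20000 nM (a limit)

In a functional assay on KYSE-70 cells for antiproliferative activity against KYSE-70 cell line (Homo sapiens), read by MTT assay, with a stated time of 72 h (on this read-out lower numbers stand for stronger inhibition and higher numbers for weaker inhibition), compound 2 gives only a limit, > 20000 nM. The whole set rests on (the limit of > 20000 nM in this assay, at which 3 of the 3 values shown sit). Compound 4 `CC(C)(C)c1ccc(-c2ccc3c(C(=O)Nc4cccc(F)c4)cc(=O)[nH]c3c2)cc1` departs from compound 2 at one place: 4-(tert-butyl)phenyl in place of fluoro on an aromatic carbon. Among the compounds with values here, the only measured step is a step that the two limits leave unreadable from compound 2 to compound 3, with fluoro in place of hydrogen on an aromatic carbon. It therefore offers no size to carry over. Only a lower number could register as a change in this assay, so stronger inhibition is the expected direction, though another reading at the limit remains quite possible. The estimated step is an at least 3.3-fold lower number from compound 2 to compound 4 (0.52 log units; beyond the scatter). For compound 4 the expected value is 6000 nM, with an estimated range from 1000 nM to 20000 nM.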

Compound 4, half-maximal inhibitory concentration: > 20000 nM
Compound 4 was reported as a limit; the forecaster's own chance of this, stated with the estimate: 45%; middle value at least 3.3-fold (0.52 log units) from the limit.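

The step from compound 2 to compound 4 cannot be read, since both values are limits: the limit of > 20000 nM in this assay, at which 4 of the 4 values shown sit. The compounds shown leave open how large a change, if any, these replacements make in this assay.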